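A few compounds are considered here, and "the series" means these few. Any claim that something is new, unique, unknown or untested is made for them only; others in the source may bear on it.

Compound 1 `CN1CCN(c2cn(S(=O)(=O)c3ccccc3Br)c3ccc(Br)cc23)CC1` and compound 2 `CN1CCN(c2cn(S(=O)(=O)c3ccc(F)cc3)c3ccc(Br)cc23)CC1` share one core and differ only in the group carried on a sulfonyl sulfur whose other neighbour is an aromatic nitrogen. In an assay on HeLa cells for displacement of a labelled ligand from 5-hydroxytryptamine receptor 6 (Homo sapiens) (a higher number here means a weaker inhibitor, a lower number a stronger inhibitor), compound 1 gives 10.2 nM, and in this assay compound 2 gives 9.2 nM. Compound 2 has the lowest of the two numbers seen, yet the step of a 1.1-fold lower number from compound 1 to compound 2 (0.04 log units; within the scatter) means the two compounds cannot be separated by this test. Compound 3 `CN1CCN(c2cn(S(=O)(=O)c3cccc(Cl)c3)c3ccc(Br)cc23)CC1` has not been measured; it carries 3-chlorophenyl in place of 4-fluorophenyl on a sulfonyl sulfur. Among the compounds with values here, the one earlier step at this same place, from compound 1 to compound 2, stayed within the scatter, and nothing else bears on the change. A further swap of the group on the sulfonyl sulfur is therefore expected to give no step beyond the scatter, a 1.1-fold higher number from compound 2 to compound 3 (0.04 log units; within the scatter). Compound 3 is thus estimated at 10 nM, with a range from 4 nM to 25 nM.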

Compound 3, inhibition constant: 7.8 nM
Compound 3: middle estimate off by 1.3-fold (0.11 log units), on the high side; measured number inside the range.
By their numbers in this assay, from the lowest: compounds 3, 2 and 1 (each within the scatter of the next).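

The step to the new group reads a 1.2-fold lower number from compound 2 to compound 3 (0.07 log units; within the scatter) in this assay, and the step from the 2-bromophenyl compound reads a 1.3-fold lower number from compound 1 to compound 3 (0.12 log units; within the scatter). What was a single unresolved swap now covers three groups: 2-bromophenyl, 4-fluorophenyl and 3-chlorophenyl on the sulfonyl sulfur cannot be separated by this test, although each carries a different halogen at a different ring position. Nothing measured here explains this match.

Halogen and ring position change together in these compounds, so their separate contributions cannot be read. As far as these compounds go, it also remains open whether the same holds for a plain phenyl, a phenyl carrying an amine or a carboxylic acid, or a group with no aromatic ring, such as cyclohexyl or a longer alkyl chain.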